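This account rests on a few compounds, and the source may have more. Where it says the series, first, only, none or still open, it means among the compounds named here.

Compound 1, `Cc1cc(C(=O)O)nn1Cc1cc(Br)ccc1OCc1ccc(F)cc1F`: in a functional assay on CHO-K1 cells for antagonist activity at prostaglandin E2 receptor EP1 subtype (Homo sapiens), read by FLIPR (a lower number here means a stronger inhibitor, a higher number a weaker inhibitor), compound 1 gives 2.63 nM.
Compound 2, `COc1ccccc1COc1ccc(Br)cc1Cn1nc(C(=O)O)cc1C`: in this assay compound 2 gives 69.2 nM.
Compound 3, `Cc1cc(C(=O)O)nn1Cc1cc(Br)ccc1OCc1cccc(Br)c1`: in this assay compound 3 gives 129 nM.

Compound 3 carries the highest number of the three. Its gap to compound 2 is within the scatter, so the two cannot be ordered; compound 1, by contrast, is the most potent of the set, and the step of a 49-fold higher number from compound 1 to compound 3 (1.69 log units; beyond the scatter) separates it from compound 3.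

Compound 4, `Cc1cc(C(=O)O)nn1Cc1cc(Br)ccc1OCc1cccc(C(F)(F)F)c1`, keeps the shared core of compound 3 and changes only the ring on the saturated carbon bound to the aromatic oxygen: trifluoromethyl in place of bromo on an aromatic carbon.

All three measured steps alter this same ring, so all three bear on the change. Replacing 2,4-difluorophenyl gave large steps, a 26-fold higher number from compound 1 to compound 2 (1.42 log units; beyond the scatter) and a 49-fold higher number from compound 1 to compound 3 (1.69 log units; beyond the scatter). Swapping one such replacement for another, 2-methoxyphenyl for 3-bromophenyl, gave a 1.9-fold higher number from compound 2 to compound 3 (0.27 log units; within the scatter), within the scatter. Trifluoromethyl for bromo is again a swap between such replacements, not a return to the 2,4-difluorophenyl of compound 1, so no step beyond the scatter is expected in this assay; the expected step is a 1.2-fold lower number from compound 3 to compound 4 (0.07 log units; within the scatter).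

Compound 4 is therefore estimated at 110 nM, with a range from 35 nM to 400 nM.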

Compound 4, inhibition constant: 1100 nM
Beside the measured number, compound 4's estimate is 10-fold (1.00 log units) below it; measured number above the stated range.
By their numbers in this assay, from the lowest: compound 1; then compounds 2 and 3 (each within the scatter of the next); then compound 4.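

The earlier steps shown here left it unclear whether this ring mattered beyond the loss of the 2,4-difluorophenyl of compound 1, since the swap of one replacement ring for another stayed within the scatter, as a 1.9-fold higher number from compound 2 to compound 3 (0.27 log units; within the scatter) shows. The new result shows that the ring is still sensitive once that 2,4-difluorophenyl has gone: in this assay, exchanging only bromo for trifluoromethyl on the same aromatic carbon, with the rest of the molecule unchanged, gives an 8.5-fold higher number from compound 3 to compound 4 (0.93 log units; beyond the scatter), so a single group at this place can matter even though two quite different rings had looked alike. Nothing measured here explains why this exchange raises the number.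

A chloro or methyl group on this same aromatic carbon would show whether bromo and trifluoromethyl mark the ends of a wider trend or whether trifluoromethyl is a special case. Going by these compounds, it also remains open whether a trifluoromethyl group costs as much on a ring that keeps fluorine atoms, such as the 2,4-difluorophenyl of compound 1.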